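This account rests on a few compounds, and the source may have more. Where it says the series, first, only, none or still open, it means among the compounds named here.

Measured compounds:
- compound 1, `CC(C)c1onc(-c2c(Cl)cccc2Cl)c1COc1ccc(-c2nc3ccc(C(=O)O)cc3n2CC(C)(C)C)cc1`: 24.8 nM in an assay on isolated protein for agonist activity at Bile acid receptor (Homo sapiens), read by TR-FRET; a lower number here means that less compound is needed, a higher number that more compound is needed for the effect
- compound 2, `CC(=O)N1CCC(n2c(-c3ccc(OCc4c(-c5c(Cl)cccc5Cl)noc4C(C)C)cc3)nc3ccc(C(=O)O)cc32)CC1`: "not determined" (no result reported) in this assay

Among the measured compounds shown here, compound 2 stands without a single number in this assay, so it gives no anchor for the step that follows. Compound 3, `CC(C)c1onc(-c2c(Cl)cccc2Cl)c1COc1ccc(-c2nc3ccc(C(=O)O)cc3n2C2CC2)cc1`, is not yet measured. It differs from compound 2 in one place: cyclopropyl in place of 1-acetylpiperidin-4-yl on an aromatic nitrogen. With no value for compound 2, the size of this step in this assay cannot be taken from data; the expectation is a step of no more than a few multiples of the usual scatter, with the direction open. The only measured point of the series is compound 1, which gives 24.8 nM in this assay, and compound 3 is expected to land in the same general region, since compound 1 shows the shared core reaching that level with another group on the same aromatic nitrogen. For compound 3 the estimate in this assay is 35 nM, with a range from 8 nM to 150 nM.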

Compound 3, half-maximal effective concentration: 117 nM
Estimate against measurement, compound 3: 3.3-fold (0.52 log units) below, within the range that was stated.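

In this assay the group on this aromatic nitrogen now has a readable effect: cyclopropyl in place of neopentyl gives a 4.7-fold higher number from compound 1 to compound 3 (0.67 log units; beyond the scatter), so the position is not indifferent to the group it carries, although compound 3 still reaches 117 nM. The step between compound 2 and compound 3 cannot be read, as compound 2 has no single number, so 1-acetylpiperidin-4-yl remains unplaced relative to the other two groups. Nothing measured here gives a reason for the shift between neopentyl and cyclopropyl.

Still open, from the compounds shown here alone, is whether the shift follows the ring in cyclopropyl or the shorter carbon framework, as this single pair cannot separate the two. An open isopropyl chain, a cyclobutyl ring or a piperidine with a free amine on the same nitrogen would each bear on that question.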